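Halogen swap on two quinone cores against WHCO1 cells

This account rests on a few compounds, and the source may have more. Where it says the series, first, only, none or still open, it means among the compounds named here.

Measured so far:
compound 1, `O=C1C=C(C(O)c2ccc(Cl)cc2)C(=O)c2ccccc21`, 3000 nM
compound 2, `O=C(C1=CC(=O)c2ccccc2C1=O)c1ccc(Cl)cc1`, 72900 nM
compound 3, `O=C1C=C(C(O)c2ccc(F)cc2)C(=O)c2ccccc21`, 5100 nM

In a functional assay on WHCO1 cells (Homo sapiens) for cytotoxicity, read by MTT assay, with a stated time of 24 h (on this read-out higher numbers stand for weaker inhibition and lower numbers for stronger inhibition), compound 1 gives 3000 nM. Compound 3, carrying (fluoro in place of chloro on an aromatic carbon), gives 5100 nM in this assay, and the step of a 1.7-fold higher number from compound 1 to compound 3 (0.23 log units; within the scatter) is small. Compound 2 stands apart: in this assay compound 2 gives 72900 nM, the highest of the three numbers, well beyond the scatter from compound 1 and from compound 3. The difference between the core of compound 1 and the core of compound 2 is not broken down here.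

Compound 4, `O=C(C1=CC(=O)c2ccccc2C1=O)c1ccc(F)cc1`, is not yet measured. It stands to compound 2 as compound 3 stands to compound 1: fluoro in place of chloro on an aromatic carbon, on the same kind of position, para to a large group, so this is the same change. For the measured compounds named here, the only guide to its size is the step from compound 1 to compound 3, which stayed within the scatter; no second instance on any core is known. The expectation is therefore a step of about a 1.4-fold higher number from compound 2 to compound 4 (0.14 log units; within the scatter) in this assay, resting on compound 1 and compound 3 showing a 1.7-fold higher number from compound 1 to compound 3 (0.23 log units; within the scatter). Compound 4 is expected to give about 100000 nM in this assay, most likely between 40000 nM and 250000 nM, near the high end of the range where a limit rather than a number may be reported.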

Compound 4, half-maximal inhibitory concentration: 74900 nM
For compound 4 the middle estimate is 1.3-fold (0.13 log units) above the measured one; measured number inside the range.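

In this assay, replacing chloro with fluoro on the second core gives a 1.0-fold higher number from compound 2 to compound 4 (0.01 log units; within the scatter), so this pair cannot be told apart on this read-out. The change reads the same on both cores, with each step and the gap between the two steps inside the scatter: the same change on two cores in this assay, a 1.7-fold higher number (0.23 log units; within the scatter) from compound 1 to compound 3 and a 1.0-fold higher number (0.01 log units; within the scatter) from compound 2 to compound 4, 1.7-fold (0.22 log units) apart, within the scatter of two such steps This supports carrying the 4-chlorophenyl to 4-fluorophenyl change between these two cores with no measurable shift in this assay, but it rests on one pair per core and does not show that the same would hold on a third core or for any other replacement.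

The compounds shown carry only chloro or fluoro on an aromatic carbon para to a large group, so it remains open whether a bromo, methoxy, amine or carboxylic acid group in that place, or a plain phenyl ring with no halogen, would leave the number equally unmoved on either core. No pair shown differs in one place within the core itself, so the large separation of the second core's compounds from those of the first remains unassigned to any single structural feature.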